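Compound 3 at the limit, with a larger sulfur substituent

The source may hold more compounds than are shown below. What is called first, only, known or untested is meant among the compounds shown, and "the series" means these compounds.

Of the compounds shown here, three have been read so far in a functional assay on HT-29 cells (Homo sapiens) for inhibition, read by MTT assay, with a stated time of 48 h (on this read-out higher numbers stand for weaker inhibition and lower numbers for stronger inhibition), and none gives a number. Compound 1 (`COc1ccc(-n2c(S)nnc2-c2cc(OC)c(OC)c(OC)c2)cc1`) gives > 60000 nM as a limit of the assay. Compound 2 (`COc1ccc(-n2c(SC)nnc2-c2cc(OC)c(OC)c(OC)c2)cc1`) gives > 60000 nM as a limit too. Compound 3 (`COc1cc(-c2nnc(SC)n2-c2ccc(N(C)C)cc2)cc(OC)c1OC`) gives > 60000 nM as well, which is again a limit and not a number. The whole series therefore stands at the limit of > 60000 nM in this assay, at which 3 of the 3 values shown sit, in these notes, and compound 3 has no readable place within it.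

Compound 4 (`COc1ccc(CSc2nnc(-c3cc(OC)c(OC)c(OC)c3)n2-c2ccc(N(C)C)cc2)cc1`) differs from compound 3 on the sulfur side chain (4-methoxyphenyl in place of hydrogen on a saturated chain carbon bound to a sulfur), where methylsulfanyl gives way to (4-methoxybenzyl)sulfanyl.

Methyl in place of hydrogen on a sulfur gave a step that the two limits leave unreadable from compound 1 to compound 2 and is the nearest precedent. Dimethylamino in place of methoxy on an aromatic carbon gave a step that the two limits leave unreadable from compound 2 to compound 3 and adds no size either. Neither step offers a size or a direction to carry over, so the expectation rests on the structural change alone, and confidence is low. Starting from a limit, the only readable move would be towards lower numbers. The expected size is an at least 10-fold lower number from compound 3 to compound 4 (1.00 log units; beyond the scatter) in the direction of stronger inhibition, with a real chance that compound 4 stays at the limit. The estimate for compound 4 is 6000 nM (150 nM to 60000 nM as the expected range).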

Compound 4, half-maximal inhibitory concentration: > 60000 nM
Compound 4: only a limit was reported (the forecaster's own chance of this, stated with the estimate: 35%); middle value at least 10-fold (1.00 log units) from the limit.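

In this assay compound 4 gives > 60000 nM as a limit and not a number, so no step can be read between compound 3 and compound 4. The compounds shown leave open the size and direction of every step in the series, and which change to the shared core, if any, would give a readable value: the limit of > 60000 nM in this assay, at which 4 of the 4 values shown sit.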